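Series notes: saturated amine swap on the shared core

The compounds below may be only part of what the source reports. "The series", "measured", "known", "first", "only" and "open" are said of these compounds alone.

Within the data shown here, compound 3 `Cn1ccc2cc(-c3ccc4oc(N5CCCC5)nc4c3)ccc21` stands highest of the three numbers so far in an assay on HEK293 cells for inhibition of Fatty-acid amide hydrolase 1 (Homo sapiens), read by fluorescence (on this read-out higher numbers stand for weaker inhibition and lower numbers for stronger inhibition), with 674 nM. Compound 1 `Cn1ccc2cc(-c3ccc4oc(Nc5ccccc5)nc4c3)ccc21` gives 48 nM and compound 2 `CN(c1ccccc1)c1nc2cc(-c3ccc4c(ccn4C)c3)ccc2o1` gives 68 nM; those two values lie within the scatter of each other (a 1.4-fold higher number from compound 1 to compound 2 (0.15 log units; within the scatter)). Both steps into compound 3 ran upward: a 14-fold higher number from compound 1 to compound 3 (1.15 log units; beyond the scatter) and a 9.9-fold higher number from compound 2 to compound 3 (1.00 log units; beyond the scatter).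

Compound 4 `Cn1ccc2cc(-c3ccc4oc(N5CCNCC5)nc4c3)ccc21` differs from compound 3 in one place: piperazin-1-yl in place of pyrrolidin-1-yl on an aromatic carbon. Among the measured compounds shown here, no measured step exchanges one saturated cyclic amine for another, so nothing bears on this change directly. What the measured steps do show is that the saturated cyclic amine on that carbon is the weakest option seen in this assay, because a 14-fold higher number from compound 1 to compound 3 (1.15 log units; beyond the scatter) and a 9.9-fold higher number from compound 2 to compound 3 (1.00 log units; beyond the scatter) both went beyond the scatter in the same direction. Compound 4 keeps a saturated ring in that position, so no step beyond the scatter, or at most a small further rise in the number, is the expectation; the step expected from compound 3 to compound 4 is a 1.6-fold higher number from compound 3 to compound 4 (0.21 log units; within the scatter). Compound 4 is therefore estimated to give 1100 nM in this assay, with a range of 350 nM to 3500 nM.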

Compound 4, half-maximal inhibitory concentration: > 1000 nM
Compound 4 was reported as a limit; the forecaster's own chance of this, stated with the estimate: 10%; the middle value is on the limit's open side.
By their numbers in this assay, from the lowest: compounds 1 and 2 (each within the scatter of the next); then compound 3. At a limit, above all of these: compound 4.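

Series notes: reading the piperazine result

In this assay the value of compound 4, > 1000 nM, is a limit and not a number: the limit of > 1000 nM in this assay, at which 1 of the 4 values shown sits.

Among these compounds, this is the first exchange of one saturated cyclic amine for another at this position, and it gives an at least 1.4-fold higher number from compound 3 to compound 4 (0.17 log units; that floor lies within the scatter), so piperazin-1-yl in place of pyrrolidin-1-yl cannot be sized and the floor alone does not separate the two rings. Against the aromatic amines the picture is firmer, with an at least 14-fold higher number from compound 2 to compound 4 (1.16 log units; beyond the scatter) and an at least 20-fold higher number from compound 1 to compound 4 (1.31 log units; beyond the scatter), so on this aromatic carbon next to the ring nitrogen and the ring oxygen, anilino and methyl(phenyl)amino now give lower numbers than both saturated rings seen, not only pyrrolidin-1-yl.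

The shift from a five-membered to a six-membered ring and the added ring nitrogen with its hydrogen arrive together in this step, so the compounds shown do not tell them apart. Piperidine, morpholine or a methyl group on the free piperazine nitrogen, each on the same carbon of the shared core, would separate those two changes.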